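Swapping a propargyl ether for an ethyl thioether on the side chain

The source may hold more compounds than are shown below. What is called first, only, known or untested is meant among the compounds shown, and "the series" means these compounds.

Three compounds share one core. Compound 1 `CCOCCn1c(N2CCN(CC)CC2)nc2ccccc21` gives 18 nM in a functional assay on ileum for inhibition of histamine H1 receptor (Cavia porcellus); on this read-out lower numbers stand for stronger inhibition and higher numbers for weaker inhibition. Compound 3 `CCOCCn1c(N2CCNCC2)nc2ccccc21` gives 11 nM in this assay, and the step of a 1.6-fold lower number from compound 1 to compound 3 (0.21 log units; within the scatter) lies within the scatter. Compound 2 `C#CCOCCn1c(N2CCN(C)CC2)nc2ccccc21` gives 12 nM in this assay, a number within the scatter of both compound 1 and compound 3. Compound 4 `CCSCCCn1c(N2CCN(C)CC2)nc2ccccc21` has not yet been measured. It differs from compound 2 by (ethylsulfanyl)methyl in place of propargyloxy on a saturated chain carbon, two bonds along the chain from an aromatic nitrogen. For the measured compounds named here, none of the measured steps touches this side chain; the only measured step concerns the ring amine, so nothing in the data indicates a direction. For compound 4 the expectation is therefore a step of a 1.3-fold higher number from compound 2 to compound 4 (0.10 log units; within the scatter), no larger than the scatter. Compound 4 is estimated at 15 nM, in a range from 5 nM to 50 nM.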

Compound 4, half-maximal inhibitory concentration: 530 nM
Compound 4: the middle estimate sits 35-fold (1.55 log units) below what was measured, outside the stated range (above it).
By their numbers in this assay, from the lowest: compounds 3, 2 and 1 (each within the scatter of the next); then compound 4.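

For the compounds shown here, this side chain is not a tolerant place: in this assay, replacing 2-(propargyloxy)ethyl with 3-(ethylsulfanyl)propyl gives a 44-fold higher number from compound 2 to compound 4 (1.65 log units; beyond the scatter), whereas the one earlier step, on the ring amine, stayed within the scatter. The two groups match in heavy atoms and hydrogen-bond acceptors, yet their numbers lie far apart. Nothing available explains this gap.

On these data alone, what counts remains open: the sulfur, the missing triple bond or the propyl chain in place of the ethyl one. A 2-(ethylsulfanyl)ethyl or 3-ethoxypropyl chain on the same core would help separate these.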